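Compound 4 Weighed Against Its Aryl Ketone Neighbours

The source may hold more compounds than are shown below. What is called first, only, known or untested is meant among the compounds shown, and "the series" means these compounds.

Compound 1 `COc1cc(-c2nnc3n2NC(c2ccco2)C(C(=O)c2ccccc2C)S3)cc(OC)c1OC` carries a (2-methylphenyl)carbonyl group on the shared core. In a functional assay on HepG2 cells (Homo sapiens) for cytotoxicity, read by MTT assay, with a stated time of 48 h (on this read-out lower numbers stand for stronger inhibition and higher numbers for weaker inhibition), compound 1 gives 63000 nM. Compound 3 `COc1cc(-c2nnc3n2NC(c2ccco2)C(C(=O)c2ccc(F)c(F)c2)S3)cc(OC)c1OC`, with a (3,4-difluorophenyl)carbonyl group, gives 52400 nM in this assay, and the step of a 1.2-fold lower number from compound 1 to compound 3 (0.08 log units; within the scatter) stays within the scatter. Compound 2 `COc1cc(-c2nnc3n2NC(c2ccco2)C(C(=O)c2ccccc2F)S3)cc(OC)c1OC` reaches in this assay only a limit, > 100000 nM. Among the numbers shown compound 1 stands highest of two, with compound 3 nearest, while one further value is a limit (the limit of > 100000 nM in this assay, at which 1 of the 3 values shown sits). The remaining steps read an at least 1.5-fold higher number from compound 1 to compound 2 (0.20 log units; that floor lies within the scatter) and an at least 1.9-fold lower number from compound 2 to compound 3 (0.28 log units; that floor lies within the scatter), each with a floor that lies within the scatter.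

Compound 4 `COc1cc(-c2nnc3n2NC(c2ccco2)C(C(=O)c2ccc(O)cc2)S3)cc(OC)c1OC` differs from compound 1 in one place: 4-hydroxyphenyl in place of 2-methylphenyl on a carbonyl carbon. The measured steps that bear on this position are a 1.2-fold lower number from compound 1 to compound 3 (0.08 log units; within the scatter) and an at least 1.5-fold higher number from compound 1 to compound 2 (0.20 log units; that floor lies within the scatter), both small, neither clearly beyond the scatter. The analyst therefore expects no step beyond the scatter in this assay, in either direction, and the expected step is a 1.1-fold lower number from compound 1 to compound 4 (0.02 log units; within the scatter). Compound 4 is estimated at 60000 nM. Compound 4 is expected to fall between 25000 nM and 150000 nM, with a real chance that the limit is reported again.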

Compound 4, half-maximal inhibitory concentration: > 100000 nM
Compound 4 was reported as a limit; the forecaster's own chance of this, stated with the estimate: 35%; middle value at least 1.6-fold (0.22 log units) from the limit.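

In this assay compound 4 is reported only as a limit, so a second group on this carbonyl carbon, the 4-hydroxyphenyl with its hydrogen-bond donor, ends without a number, as the 2-fluorophenyl of compound 2 did: the limit of > 100000 nM in this assay, at which 2 of the 4 values shown sit.

The readable steps are an at least 1.5-fold higher number from compound 1 to compound 4 (0.20 log units; that floor lies within the scatter) and an at least 1.9-fold higher number from compound 3 to compound 4 (0.28 log units; that floor lies within the scatter); both are floors, so the true gaps may be wider, but neither shows a change beyond the scatter on its own. The step between compound 2 and compound 4 cannot be read, as both values are limits.

The compounds shown hold only substituted phenyl groups at this position, so they leave open whether an amine, a carboxylic acid or a longer alkyl chain in place of the 2-methylphenyl of compound 1 would move the number beyond the scatter. They also leave open how far past the limit compound 2 and compound 4 lie, and whether the two differ at all.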